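Ring size on the arylamine nitrogen: compound 3 to compound 4

This account rests on a few compounds, and the source may have more. Where it says the series, first, only, none or still open, it means among the compounds named here.

Compound 3 `CC(C)(C)c1cc(NC(=O)c2c(Cl)cc(NC3CCCC3)cc2Cl)ccc1O` gives 5000 nM in an assay on isolated protein for antagonist activity at Bile acid receptor (Homo sapiens), read by HTRF, with a stated time of 30 min (a higher number here means a weaker inhibitor, a lower number a stronger inhibitor), the lowest number among the three measured compounds. Compound 1 `CC(C)(C)c1cc(NC(=O)c2c(Cl)cc(NCc3ccncc3)cc2Cl)ccc1O` gives 9800 nM, and the step of a 2.0-fold lower number from compound 1 to compound 3 (0.29 log units; within the scatter) lies within the scatter. Among the measured compounds shown here, compound 2 `CNc1cc(Cl)c(C(=O)Nc2ccc(O)c(C(C)(C)C)c2)c(Cl)c1` gives 13900 nM, and the step of a 2.8-fold lower number from compound 2 to compound 3 (0.44 log units; beyond the scatter) is the only one of the three steps that goes beyond the scatter. Between compound 1 and compound 2 the step of a 1.4-fold higher number from compound 1 to compound 2 (0.15 log units; within the scatter) also stays within the scatter.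

Compound 4 `CC(C)(C)c1cc(NC(=O)c2c(Cl)cc(NC3CCCCC3)cc2Cl)ccc1O` differs from compound 3 in one place: cyclohexyl in place of cyclopentyl on a nitrogen on an aromatic ring. Both earlier steps bear on this position, since each replaced the group on the same nitrogen. The exchange of methyl for cyclopentyl, a 2.8-fold lower number from compound 2 to compound 3 (0.44 log units; beyond the scatter), was modest, and the exchange of (pyridin-4-yl)methyl for cyclopentyl, a 2.0-fold lower number from compound 1 to compound 3 (0.29 log units; within the scatter), stayed within the scatter. A cyclohexyl group is far closer in kind to the cyclopentyl it replaces than either methyl or (pyridin-4-yl)methyl was, so no step beyond the scatter is expected in this assay. Compound 4 is therefore expected to give about 4000 nM in this assay, within a range from 2000 nM to 10000 nM. The step of a 1.3-fold lower number from compound 3 to compound 4 (0.10 log units; within the scatter) that this estimate means is expected to remain within the scatter.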

Compound 4, half-maximal inhibitory concentration: 2500 nM
Estimate against measurement, compound 4: 1.6-fold (0.20 log units) above, and the stated range covers the measured number.
By their numbers in this assay, from the lowest: compounds 4, 3, 1 and 2 (each within the scatter of the next, the first and the last beyond it).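

In this assay, the exchange of cyclopentyl for cyclohexyl on this nitrogen gives a 2.0-fold lower number from compound 3 to compound 4 (0.30 log units; within the scatter), so the two carbon rings cannot be told apart at this position. The cyclohexylamino compound is nevertheless the first to stand clear of the (pyridin-4-yl)methyl group, with a 3.9-fold lower number from compound 1 to compound 4 (0.59 log units; beyond the scatter), a separation that the cyclopentyl group did not reach, while the exchange from methyl gives a 5.6-fold lower number from compound 2 to compound 4 (0.75 log units; beyond the scatter), so both of these steps are beyond the scatter but remain modest. Nothing shown here gives a reason for any of these steps.

The compounds shown leave open whether a larger carbon ring such as cycloheptyl, or a ring carrying an added group such as an amine or a carboxylic acid, would move the number further than cyclohexyl does on this nitrogen. They also leave open whether a longer open carbon chain in place of the ring would give a number like those of the cyclic groups, and so whether a ring is needed here at all.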